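Aryl triazole series: trifluoromethoxy to fluoro, cytotoxicity

The compounds below may be only part of what the source reports. "The series", "measured", "known", "first", "only" and "open" are said of these compounds alone.

Measured in an ADME assay on HeLa cells (Homo sapiens) for cytotoxicity, read by sulforhodamine B assay, with a stated time of 48 h, tested at 10 uM; on this read-out lower numbers stand for less inhibition and higher numbers for more inhibition at the one concentration tested (going by the name of the read-out):
compound 1 `CCCCCCCc1cn(C(c2ccccc2)c2cc3cc(Br)ccc3nc2OC)nn1` gives 9.7%
compound 2 `COc1nc2ccc(Br)cc2cc1C(c1ccccc1)n1cc(-c2cccc(F)c2)nn1` gives 9.04%
compound 3 `COc1nc2ccc(Br)cc2cc1C(c1ccccc1)n1cc(-c2ccc(OC(F)(F)F)cc2)nn1` gives -2.24%

Compound 3 has the lowest of the three numbers in this assay. Its nearest neighbour is compound 2, a number 11.3 percentage points lower from compound 2 to compound 3 (beyond the scatter); furthest is compound 1, a number 11.9 percentage points lower from compound 1 to compound 3 (beyond the scatter). Between the two others the difference is small: a number 0.7 percentage points lower from compound 1 to compound 2 (within the scatter).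

Compound 4 `COc1nc2ccc(Br)cc2cc1C(c1ccccc1)n1cc(-c2ccc(F)cc2)nn1` is not yet measured. It differs from compound 3 in one place: fluoro in place of trifluoromethoxy on an aromatic carbon.

Among the compounds with values here, no measured step exchanges fluoro for trifluoromethoxy on the same carbon. Within the data shown here, the step that bears most is the one from compound 2 to compound 3, where a phenyl bearing fluoro was replaced by one bearing trifluoromethoxy, with a modest drop: a number 11.3 percentage points lower from compound 2 to compound 3 (beyond the scatter). Among the measured compounds shown here, the move toward compound 4 undoes the trifluoromethoxy, so a modest rise in this assay is expected, roughly back toward the levels of compound 1 and compound 2, though the two fluoro positions differ and only one comparison supports this. The expected step is a number 8.2 percentage points higher from compound 3 to compound 4 (within the scatter).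

Compound 4 is therefore estimated at 6% in this assay, with a range from -6% to 18%.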

Compound 4, a percentage reported as inhibition, at one concentration (the size of the read-out at that concentration, not a potency): 4.27%
Estimate against measurement, compound 4: 1.7 percentage points above; the measured number falls inside the stated range.
By their numbers in this assay, from the lowest: compounds 3, 4, 2 and 1 (each within the scatter of the next, the first and the last beyond it).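

Within the data shown here, the direct exchange at this position, on an aromatic carbon para to a large group, had no earlier counterpart: fluoro in place of trifluoromethoxy gives a number 6.5 percentage points higher from compound 3 to compound 4 (within the scatter) in this assay, so this pair does not separate the two groups. The 4-fluorophenyl compound is likewise not separated from its 3-fluorophenyl or heptyl analogues, with a number 4.8 percentage points lower from compound 2 to compound 4 (within the scatter) and a number 5.4 percentage points lower from compound 1 to compound 4 (within the scatter), so moving the fluoro and replacing the heptyl chain with 4-fluorophenyl both stay inside the scatter, and compound 4 cannot be placed apart from any of the other three, although compound 3 remains beyond the scatter of compound 1 and compound 2. Nothing available here accounts for these numbers.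

As far as these compounds go, it remains open whether a group of another kind at this position, such as an amine or a carboxylic acid on the phenyl ring, would move the number clearly beyond the scatter in this assay. With a single concentration per compound, these percentages also leave potency undefined, and the shared core stays unvaried throughout the compounds shown.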